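An Ethoxy Chain Replaces a Butyl Chain in Compound 3

The source may report more compounds than this note shows. Statements on the series, on what has been measured and on what is new or still open speak of the compounds shown alone.

Compound 1 `COc1cc2c(Nc3ccc(F)c(Cl)c3)ncnc2cc1OCCCn1ccnc1[N+](=O)[O-]`: 2060 nM
Compound 2 `COc1cc2c(Nc3ccc(F)c(Cl)c3)ncnc2cc1OCCCCCCn1ccnc1[N+](=O)[O-]`: 1840 nM

Going by the values given here, both values come from a functional assay on HT-29 cells (Homo sapiens) for inhibition, read by sulforhodamine B assay, with a stated time of 72 h (a lower number here means a stronger inhibitor, a higher number a weaker inhibitor), and in it compound 2 stands within the scatter of compound 1, the only other compound measured so far. Compound 3 `COc1cc2c(Nc3ccc(F)c(Cl)c3)ncnc2cc1OCCOCCn1ccnc1[N+](=O)[O-]` has not yet been measured. It differs from compound 2 by 2-(2-nitro-1H-imidazol-1-yl)ethoxy in place of 4-(2-nitro-1H-imidazol-1-yl)butyl on a saturated chain carbon, two bonds along the chain from an oxygen on an aromatic ring.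

Among the compounds with values here, only one measured step bears on this change: a 1.1-fold lower number from compound 1 to compound 2 (0.05 log units; within the scatter). That step altered the chain attached at the same oxygen and stayed within the scatter. Within the data shown here, it is weak evidence, however, as no measured compound carries an oxygen within this chain. No shift beyond the scatter is therefore expected in this assay, and no direction can be favoured with confidence. The expected step is a 1.1-fold higher number from compound 2 to compound 3 (0.04 log units; within the scatter). For compound 3 the estimated value is 2000 nM, with an expected range of 1100 nM to 3800 nM.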

Compound 3, half-maximal inhibitory concentration: 5520 nM
Compound 3: middle estimate off by 2.8-fold (0.44 log units), on the low side; the measured number lies above the stated range.
By their numbers in this assay, from the lowest: compounds 2 and 1 (each within the scatter of the next); then compound 3.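

Setting an oxygen inside the chain, with 2-(2-nitro-1H-imidazol-1-yl)ethoxy in place of 4-(2-nitro-1H-imidazol-1-yl)butyl, is the first change here that moves the number in this assay beyond the scatter, giving a 3.0-fold higher number from compound 2 to compound 3 (0.48 log units; beyond the scatter), and the comparison with the shorter chain gives a 2.7-fold higher number from compound 1 to compound 3 (0.43 log units; beyond the scatter). The earlier step, a 1.1-fold lower number from compound 1 to compound 2 (0.05 log units; within the scatter), had shown the chain at this position tolerating a change of length without a clear shift, whereas compound 3 stands apart from both earlier compounds, though only modestly, so among these three compounds what the chain is made of counts for more than its length. Nothing available accounts for this shift.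

The compounds leave open whether the weaker number belongs to the ether oxygen itself or to where it stands in the chain, as only compound 3 carries one. They also leave open how this assay would read for a longer chain holding the same oxygen, or for a chain holding an amine in its place.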